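The source may hold more compounds than are shown below. What is called first, only, known or untested is meant among the compounds shown, and "the series" means these compounds.

In a functional assay on A-375 cells (Homo sapiens) for antiproliferative activity (on this read-out lower numbers stand for stronger inhibition and higher numbers for weaker inhibition), compound 1 `O=C(Nc1ccc(-c2cscn2)cc1)C1CCCN(Cc2ccc(F)c(F)c2)C1` gives 880 nM. Compound 2 `O=C(Nc1ccc(-c2cscn2)cc1)C1CCN(Cc2ccc(F)c(F)c2)CC1` gives > 20000 nM, which is a limit. Compound 3 `O=C(Nc1ccc(-c2cscn2)cc1)C1CCCN(C(=O)c2ccc(F)c(F)c2)C1` also gives only a limit, > 20000 nM. It therefore stands at the limit of > 20000 nM in this assay, at which 2 of the 3 values shown sit.

Compound 4 `O=C(Nc1ccc(-c2cscn2)cc1)C1CCCN(Cc2cccc(F)c2)C1` differs from compound 3 by 3-fluorobenzyl in place of (3,4-difluorophenyl)carbonyl on an amine nitrogen in a ring. The closest measured step is an at least 22-fold higher number from compound 1 to compound 3 (1.35 log units; beyond the scatter), a large change at that same nitrogen. Read in reverse, it points to a large move towards a lower number in this assay. Within the data shown here, no measured step covers 3-fluorobenzyl against 3,4-difluorobenzyl, so the range stays wide. The expected step is an at least 16-fold lower number from compound 3 to compound 4 (1.22 log units; beyond the scatter). For compound 4 the estimate is 1200 nM, with an expected range of 400 nM to 6000 nM.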

Compound 4, half-maximal inhibitory concentration: 2450 nM
Estimate against measurement, compound 4: 2.0-fold (0.31 log units) below, within the range that was stated.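

A second benzyl group now gives a measured value where the carbonyl-linked compound does not, so the gain at this ring nitrogen is not tied to 3,4-difluorobenzyl alone: an at least 8.1-fold lower number from compound 3 to compound 4 (0.91 log units; beyond the scatter). Compound 3 is held only at a limit, so this step gives a minimum size: the limit of > 20000 nM in this assay, at which 2 of the 4 values shown sit. The fluorine on the benzyl ring also counts, since losing one gives a 2.8-fold higher number from compound 1 to compound 4 (0.44 log units; beyond the scatter).

Still open, on these data alone, is how a benzyl ring without fluorine, or with chloro or methoxy, would read. As far as these compounds go, a longer chain between this nitrogen and the aromatic ring also remains untested here.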